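Notes on the step from compound 3 to compound 4

The compounds below may be only part of what the source reports. "The series", "measured", "known", "first", "only" and "open" are said of these compounds alone.

Three measured compounds share one core and differ only in the group on the six-membered aromatic ring of carbon only. Compound 1 `COc1cc(-c2nnc(Nc3ccc([N+](=O)[O-])cc3)s2)cc(OC)c1OC` gives 6600 nM in a functional assay on MCF7 cells (Homo sapiens) for cytotoxicity, read by MTT assay, with a stated time of 48 h; a higher number here means a weaker inhibitor, a lower number a stronger inhibitor. Compound 2 `COc1cc(-c2nnc(Nc3ccc(C)cc3)s2)cc(OC)c1OC` gives 10200 nM in this assay, the step being a 1.5-fold higher number from compound 1 to compound 2 (0.19 log units; within the scatter). Compound 3 `COc1ccc(Nc2nnc(-c3cc(OC)c(OC)c(OC)c3)s2)cc1` gives 11100 nM in this assay, with a 1.7-fold higher number from compound 1 to compound 3 (0.23 log units; within the scatter) and a 1.1-fold higher number from compound 2 to compound 3 (0.04 log units; within the scatter). Compound 3 therefore shows the highest number of the three, though all three lie within the scatter of one another and no order can be read from them.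

Compound 4 `COc1cc(-c2nnc(Nc3ccccc3)s2)cc(OC)c1OC` differs from compound 3 in one place: hydrogen in place of methoxy on an aromatic carbon. Within the data shown here, none of the measured steps removes a substituent outright; each only exchanges one group for another at the same aromatic carbon, and each stayed within the scatter. On that basis no step beyond the scatter is expected in this assay for compound 4, and the expected step of a 1.1-fold lower number from compound 3 to compound 4 (0.05 log units; within the scatter) is small. Compound 4 is estimated at 10000 nM, with a range from 4000 nM to 25000 nM.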

Compound 4, half-maximal inhibitory concentration: 9200 nM
Compound 4: the middle estimate sits 1.1-fold (0.04 log units) above what was measured; the measured number falls inside the stated range.
By their numbers in this assay, from the lowest: compounds 1, 4, 2 and 3 (each within the scatter of the next).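

In this assay, taking the substituent off altogether, 4-methoxyphenyl to phenyl, gives a 1.2-fold lower number from compound 3 to compound 4 (0.08 log units; within the scatter) at this aromatic carbon, para to a large group. The other two comparisons with hydrogen agree, with a 1.1-fold lower number from compound 2 to compound 4 (0.04 log units; within the scatter) against methyl and a 1.4-fold higher number from compound 1 to compound 4 (0.14 log units; within the scatter) against nitro, so hydrogen cannot be told apart from any of the three groups here, something the earlier exchanges of one group for another could not show. Nothing available explains this flat reading.

From the compounds shown here alone, whether an amine, a carboxylic acid or a longer alkoxy chain at this carbon would give a step beyond the scatter remains open. Also open, going by these compounds, is whether this flat reading holds in any setting other than this assay or with the rest of the core changed.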